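This account rests on a few compounds, and the source may have more. Where it says the series, first, only, none or still open, it means among the compounds named here.

Values in an ADME assay on HEK293 cells (Homo sapiens) for cytotoxicity, read by luminescence, with a stated time of 72 h (on this read-out higher numbers stand for lower toxicity in this test and lower numbers for higher toxicity in this test), for the compounds measured so far:

- Compound 1 `COc1cccc(-c2nc(SCC(=O)Nc3nc(-c4cc(Cl)c(N)c(Cl)c4)c[nH]3)[nH]c(=O)c2C#N)c1` gives > 50000 nM as a limit
- Compound 2 `COc1cccc(-c2nc(SCC(=O)Nc3nc(-c4cccc(Br)c4)cs3)[nH]c(=O)c2C#N)c1` gives > 50000 nM as a limit
- Compound 3 `CCOc1cccc(-c2nc(SCC(=O)Nc3nc(-c4cc(Cl)c(N)c(Cl)c4)cs3)[nH]c(=O)c2C#N)c1` gives > 50000 nM as a limit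

Compound 2 stands only at a limit and has no exact number, like the other two compounds. Compound 4 `COc1cccc(-c2nc(SCC(=O)Nc3nc(-c4cc(Cl)c(N)c(Cl)c4)cs3)[nH]c(=O)c2C#N)c1` has 4-amino-3,5-dichlorophenyl in place of 3-bromophenyl on an aromatic carbon. Compound 1 and compound 3 already carry that same group, and neither gave more than a limit. No step beyond the usual scatter is expected in this assay because of the pattern so far (the limit of > 50000 nM in this assay, at which 3 of the 3 values shown sit). The expected change is a number no higher from compound 2 to compound 4 (the limit leaves the size open) as estimated here. Compound 4 is expected at about 50000 nM (estimated range 20000 nM to 100000 nM).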

Compound 4, half-maximal cytotoxic concentration: > 50000 nM
Compound 4 was reported as a limit; the forecaster's own chance of this, stated with the estimate: 85%; the middle value sits exactly at the limit.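

Neither the step from compound 2 to compound 4 nor the step from compound 3 to compound 4 can be read, because both ends of each step are limits, not numbers: the limit of > 50000 nM in this assay, at which 4 of the 4 values shown sit. The compounds shown leave open whether any of them truly differs from another in this assay.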